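Series notes: a chloro step from compound 2 to compound 3

The source may report more compounds than this note shows. Statements on the series, on what has been measured and on what is new or still open speak of the compounds shown alone.

compound 1 `O=C(NC1CCCCC1)NS(=O)(=O)N1CCC(CCNC(=O)c2ccnc3ccccc23)CC1`: 16%
compound 2 `O=C(NC1CCCCC1)NS(=O)(=O)N1CCC(CCNC(=O)c2cccc3cccnc23)CC1`: 37%

Among the measured compounds shown here, in a functional assay on the whole organism (blood) with Rattus norvegicus as the target, with stated times of 24 h and 1 h, at a dose of 5 mg/kg by the intraperitoneal route (a higher number here means a stronger effect of the compound at the dose given, a lower number a weaker effect), compound 2 gives 37%, the higher of the two numbers measured so far, while compound 1 gives 16%. For the measured compounds named here, the one measured step, a number 21 percentage points higher from compound 1 to compound 2 (beyond the scatter), lies beyond the scatter and concerns the point of attachment of the amide ring. Compound 3 `O=C(NC1CCCCC1)NS(=O)(=O)N1CCC(CCNC(=O)c2cc(Cl)cc3cccnc23)CC1` differs from compound 2 by chloro in place of hydrogen on an aromatic carbon. Going by the values given here, no measured step involves a chloro entering an aromatic carbon, so nothing bears on this change. With no guide, the expected step of no change at the digits printed from compound 2 to compound 3 (within the scatter) is none beyond the scatter. Compound 3 is therefore estimated at 37% in this assay, with a wide range from 15% to 60%.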

Compound 3, a percentage reported as activity, at one dose (the size of the read-out at that dose, not a potency): 52%
The estimate for compound 3 lay 15 percentage points below the measured number; measured number inside the range.
By their numbers in this assay, from the lowest: compound 1; then compound 2; then compound 3.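

Chloro in place of hydrogen on this aromatic carbon of the quinolin-8-yl group gives a number 15 percentage points higher from compound 2 to compound 3 (beyond the scatter) in this assay, so this position accepts a substituent without loss of the read-out. Set against the quinolin-4-yl group, 6-chloroquinolin-8-yl gives a number 36 percentage points higher from compound 1 to compound 3 (beyond the scatter). No evidence on the cause of either rise is at hand. From the compounds shown here alone, whether fluoro, methyl or methoxy at this place would match chloro remains open, as does whether chloro would give a similar rise on the quinolin-4-yl group of compound 1.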